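Removing the trifluoromethyl group from compound 2

The source may report more compounds than this note shows. Statements on the series, on what has been measured and on what is new or still open speak of the compounds shown alone.

Values from a functional assay on RAW264.7 cells (Mus musculus), with a stated time of 3 days (on this read-out higher numbers stand for weaker inhibition and lower numbers for stronger inhibition), are these:
Compound 1 (`COc1cnc(-c2ccccn2)nc1NCc1ccccc1C`) gives 220 nM
Compound 2 (`COc1cnc(-c2ccccn2)nc1NCc1ccccc1C(F)(F)F`) gives 230 nM
Compound 3 (`COc1cnc(-c2ccccn2)nc1C1CCCC1`) gives 1800 nM

Compound 2 shares the low end of these three numbers with compound 1, while compound 3 lies clearly higher. The next compound to consider, compound 4 (`COc1cnc(-c2ccccn2)nc1NCc1ccccc1`), has hydrogen in place of trifluoromethyl on an aromatic carbon, ortho to a large group (hydrogen in place of trifluoromethyl on an aromatic carbon). Its number in this assay is not yet known.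

For the measured compounds named here, one measured step bears on this place. Putting trifluoromethyl in place of methyl gave a 1.0-fold higher number from compound 1 to compound 2 (0.02 log units; within the scatter) at the same position on the ring. Going by the values given here, the two groups thus gave matching numbers, but neither is hydrogen, and no measured compound has hydrogen there. Compound 3 differs from compound 2 by more than one change, so it offers no direct guide. The data therefore point to no clear shift in either direction, although the missing direct comparison calls for a wide range. The expected result is a 1.1-fold higher number from compound 2 to compound 4 (0.04 log units; within the scatter) with no step beyond the scatter foreseen. Compound 4 is estimated at 250 nM with an expected range of 100 nM to 600 nM for its value.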

Compound 4, half-maximal inhibitory concentration: 420 nM
Estimate against measurement, compound 4: 1.7-fold (0.23 log units) below; measured number inside the range.
By their numbers in this assay, from the lowest: compounds 1, 2 and 4 (each within the scatter of the next); then compound 3.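

In this assay this place on the ring can now be read with hydrogen as well as with two larger groups: hydrogen in place of trifluoromethyl gives a 1.8-fold higher number from compound 2 to compound 4 (0.26 log units; within the scatter) and hydrogen in place of methyl gives a 1.9-fold higher number from compound 1 to compound 4 (0.28 log units; within the scatter) so neither step can be told apart from the ordinary spread of repeated measurements. The earlier pair showed only that methyl and trifluoromethyl could not be separated, whereas these steps extend that finding to the bare aromatic carbon, ortho to a large group, and show that in these three compounds this read-out does not depend on having either group there. No measurement available here accounts for this result, so nothing can be said about its cause.

Still open is whether a methoxy group, an amine or a carboxylic acid on this carbon would also stay within the scatter of these three compounds, since all the groups shown here are small and none carries oxygen or nitrogen. The compounds shown also leave open whether a longer chain here, or a group of this kind on another carbon of the same ring, would shift the number.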